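This account rests on a few compounds, and the source may have more. Where it says the series, first, only, none or still open, it means among the compounds named here.

Measured compounds:
compound 1 `Cn1ncc2c(-c3ccc(F)cc3)cc(NNC(=O)Nc3cc(Cl)cc(Cl)c3)nc21`: 54300 nM
compound 2 `Cc1nn(C)c2nc(NNC(=O)Nc3cc(Cl)nc(Cl)c3)cc(-c3ccc(Cl)s3)c12`: 29400 nM

In a functional assay on SW620/5-FU cells (Homo sapiens) for cytotoxicity, read by MTT assay, with a stated time of 48 h, in the presence of a further agent that is not named here (on this read-out higher numbers stand for an effect only at larger amounts of compound and lower numbers for an effect already at smaller amounts), compound 2 gives 29400 nM, and compound 1 gives 54300 nM in this assay. Compound 2 holds the lower of the two numbers, yet its gap to compound 1 lies within the usual scatter, so the two cannot be told apart on these data. Compound 3 `Cc1nn(C)c2nc(NNC(=O)Nc3cc(Cl)nc(Cl)c3)cc(C3CC3)c12` is not yet measured. It differs from compound 2 in one place: cyclopropyl in place of 5-chlorothiophen-2-yl on an aromatic carbon. Going by the values given here, no step between measured compounds covers a change of this kind, so any expectation rests on the two values alone and on the change itself. The expected step of a 1.5-fold higher number from compound 2 to compound 3 (0.18 log units; within the scatter) is toward a higher number and is estimated to stay close to the scatter. For compound 3 the estimate in this assay is 45000 nM, with a range from 15000 nM to 130000 nM.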

Compound 3, half-maximal effective concentration: 80800 nM
Compound 3: the middle estimate sits 1.8-fold (0.25 log units) below what was measured, within the range that was stated.
By their numbers in this assay, from the lowest: compounds 2, 1 and 3 (each within the scatter of the next, the first and the last beyond it).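

In this assay, cyclopropyl in place of 5-chlorothiophen-2-yl on the aromatic carbon opposite the ring nitrogen brings a 2.7-fold higher number from compound 2 to compound 3 (0.44 log units; beyond the scatter) and this is the only step shown at this position. It shows that the number responds to what this position carries: with a three-membered non-aromatic ring of carbon only in place of a five-membered aromatic ring, the effect appears only at larger amounts of compound. Nothing measured here accounts for this shift.

The compounds shown leave open whether an amine such as morpholine, an open chain such as propyl or an unsubstituted thiophene at this position would stay near compound 2 or near compound 3. This single step also cannot separate the part of the chlorine from that of the ring it sits on.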